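Sulfate on a glycolipid core: weighing a second sulfation

The source may report more compounds than this note shows. Statements on the series, on what has been measured and on what is new or still open speak of the compounds shown alone.

In a functional assay on U-373MG ATCC cells (Homo sapiens), read by thymidine incorporation (on this read-out lower numbers stand for stronger inhibition and higher numbers for weaker inhibition), the measured compounds stand as follows:

compound 1 `CCCCCCCC/C=C\CCCCCCCCO[C@H]1O[C@H](CO)[C@@H](O)[C@H](O)[C@H]1NC(C)=O` gives 4.6 uM
compound 2 `CCCCC(=O)N[C@H]1[C@@H](OCCc2ccccc2)O[C@H](COCC(CO)(CO)COS(=O)(=O)O)[C@@H](O)[C@@H]1O` gives 6.7 uM
compound 3 `CCCCC(=O)N[C@H]1[C@@H](OCCc2ccccc2)O[C@H](COCC(CO)(CO)CO)[C@@H](O)[C@@H]1O` gives only a limit of the assay, > 50 uM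

Compound 3 and compound 2 share a core, and the difference between the two cores of compound 1 and compound 3 is not broken down here. The change from compound 3 to compound 2 is sulfo in place of hydrogen on an oxygen on a saturated carbon. It produced an at least 7.4-fold lower number from compound 3 to compound 2 (0.87 log units; beyond the scatter), a step that rests on the limit of > 50 uM in this assay, at which 1 of the 3 values shown sits, for compound 3 and so is known only as a bound. Compound 1 stands closest to compound 2, and the two values lie within the scatter of each other.

Compound 4 `CCCCCCCC/C=C\CCCCCCCCO[C@H]1O[C@H](CO)[C@@H](O)[C@H](OS(=O)(=O)O)[C@H]1NC(C)=O` is not yet measured. It differs from compound 1 by sulfo in place of hydrogen on an oxygen on a saturated carbon. This is the same kind of change as that from compound 3 to compound 2, but the place is not the same: in compound 2 the oxygen sits on a saturated carbon whose other neighbour is a saturated chain carbon, whereas in compound 4 that carbon's other neighbours are saturated ring carbons. Within the data shown here, because the one measured instance, an at least 7.4-fold lower number from compound 3 to compound 2 (0.87 log units; beyond the scatter), lowered the number beyond the scatter, a step in the same direction is expected from compound 1 to compound 4, though its size on a different place is uncertain: the expected step is a 2.3-fold lower number from compound 1 to compound 4 (0.36 log units; beyond the scatter). Compound 4 is estimated to give 2 uM, with a plausible range from 0.5 uM to 8 uM.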

Compound 4, concentration for 50% inhibition: 9.6 uM
Estimate against measurement, compound 4: 4.8-fold (0.68 log units) below, outside the stated range (above it).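

On the core of compound 1, the hydroxy to sulfooxy change gave a 2.1-fold higher number from compound 1 to compound 4 (0.32 log units; beyond the scatter) in this assay, so the direction seen on the other core did not carry over, and the two steps clearly part: the same change on two cores in this assay, an at least 7.4-fold lower number (0.87 log units; beyond the scatter) from compound 3 to compound 2 and a 2.1-fold higher number (0.32 log units; beyond the scatter) from compound 1 to compound 4, at least 15-fold (1.19 log units) apart, beyond the scatter of two such steps. Compound 3 is known only through a limit of the assay, so the earlier step and the gap between the two steps are bounds rather than exact sizes: the limit of > 50 uM in this assay, at which 1 of the 4 values shown sits. The result shows that the outcome of this change cannot be assumed from one core to the other in this series, but it does not show why, as the two pairs differ in both the core and the place of the oxygen that carries the group.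

The compounds shown leave open whether a sulfooxy group on another oxygen of compound 1 would lower the number as it did on the other core. They also leave open whether a phosphate or a carboxylic acid in its place would follow either step.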